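Trimming the Amide Substituent: From Compound 3 to Compound 4

This account rests on a few compounds, and the source may have more. Where it says the series, first, only, none or still open, it means among the compounds named here.

Compound 1: `C[C@@H](NC(=O)c1ccc(C#Cc2ccncc2)cn1)C(C)(C)O` — 22.4%
Compound 2: `C[C@@H](NC(=O)c1ccc(C#Cc2cccc(F)c2)nc1)C(C)(C)O` — 26.6%
Compound 3: `C[C@@H](NC(=O)c1ccc(C#Cc2cccc(F)c2)cn1)C(C)(C)C` — 31.2%

All three numbers come from an ADME assay on HEK293 cells for agonist activity at metabotropic glutamate receptor 5 (Rattus norvegicus), read by fluorescence and calcium flux (on this read-out higher numbers stand for larger maximal responses and lower numbers for smaller maximal responses), and all three are modest maximal responses. Compound 3 carries the highest of the three numbers, yet the gap to compound 2 and the gap to compound 1 both lie within the usual scatter, so the three compounds cannot be put in an order on these data alone.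

Compound 4 `CCCNC(=O)c1ccc(C#Cc2cccc(F)c2)cn1` has not yet been measured in this assay. It differs from compound 3 in one place: propyl in place of 1,2,2-trimethylpropyl on an amide-type nitrogen. Among the compounds with values here, no other pair among the measured compounds shares this change, so there is no measured step to lean on. With the amide substituent reduced from a branched six-carbon group to a straight three-carbon chain, while the rest of compound 3 is kept, the step of a number 9.2 percentage points lower from compound 3 to compound 4 (within the scatter) is expected to be small and, if anything, downward, not clearly beyond the scatter. Compound 4 is therefore estimated to reach 22% in this assay, within a range of 8% to 38%.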

Compound 4, largest response reached (reported as efficacy), in percent of the reference or control that the assay uses: 8.3%
Compound 4: the middle estimate sits 13.7 percentage points above what was measured; the range from low to high includes it.
By their numbers in this assay, from the lowest: compound 4; then compounds 1, 2 and 3 (each within the scatter of the next).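

In this assay, within the data shown here, the change on the amide-type nitrogen gives the first step that can be read, since no earlier pair differs in one place only. It comes out as a number 22.9 percentage points lower from compound 3 to compound 4 (beyond the scatter) and so shows that the maximal response depends on the amide substituent, with the rest of compound 3 kept, by more than the scatter can account for. Yet propyl in place of 1,2,2-trimethylpropyl removes carbons, branching and the defined stereocentre all at once, so this single step cannot separate them, and nothing available gives a reason for it.

As far as these compounds go, what remains open is where along the way from propyl to 1,2,2-trimethylpropyl the response returns, for instance whether a longer chain such as butyl or pentyl, or a compact branched group such as isopropyl, tert-butyl or cyclopropyl, would hold it on the same core. Equally open, from the compounds shown here alone, is how much the defined stereocentre itself contributes, which only the mirror-image form of compound 3 could show, and whether an amide substituent carrying an amine or a carboxylic acid would behave like either group.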